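A few compounds are considered here, and "the series" means these few. Any claim that something is new, unique, unknown or untested is made for them only; others in the source may bear on it.

Measured so far in a functional assay on EOL1 cells (Homo sapiens) for inhibition, read by fluorescence, with a stated time of 72 h; on this read-out higher numbers stand for weaker inhibition of growth and lower numbers for stronger inhibition of growth:
- Compound 1 `CCCCCCn1cnc2c(Nc3ccc(Cl)cc3)nc(N[C@H]3CC[C@H](N)CC3)nc21`: 440 nM
- Compound 2 `N[C@H]1CC[C@H](Nc2nc(Nc3ccc(Cl)cc3)c3ncn(C4CCCCC4)c3n2)CC1`: 140 nM

Compound 1, at 440 nM, holds the higher of the two numbers in this assay, so it is the weaker growth inhibitor of this pair. The next compound, compound 3 `CCCCCCn1cnc2c(Nc3cc(OC)cc(OC)c3)nc(N[C@H]3CC[C@H](N)CC3)nc21`, keeps the hexyl group of compound 1 and changes another part of the molecule: 3,5-dimethoxyphenyl in place of 4-chlorophenyl on a nitrogen on an aromatic ring. In short, 3,5-dimethoxyphenyl stands in place of 4-chlorophenyl on a nitrogen on an aromatic ring.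

For the measured compounds named here, only one measured step exists, a 3.1-fold lower number from compound 1 to compound 2 (0.50 log units; beyond the scatter), and it concerns the swap of hexyl for cyclohexyl, not this group. It therefore says nothing about direction here and serves only as a rough guide to how far one swap has moved the number in this series. Going by the values given here, no measured compound shows how the new group behaves, so the direction is an uncertain judgement. A modest move toward weaker inhibition is expected, of similar size to that single step. The expected change is a 1.5-fold higher number from compound 1 to compound 3 (0.17 log units; within the scatter). The estimate for compound 3 is 650 nM, with an expected range from 150 nM to 2800 nM.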

Compound 3, concentration for 50% growth inhibition: 380 nM
Beside the measured number, compound 3's estimate is 1.7-fold (0.23 log units) above it; low and high end bracket the measured number.
By their numbers in this assay, from the lowest: compound 2; then compounds 3 and 1 (each within the scatter of the next).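

In this assay, replacing 4-chlorophenyl with 3,5-dimethoxyphenyl gives a 1.2-fold lower number from compound 1 to compound 3 (0.06 log units; within the scatter), so the two compounds cannot be told apart on this read-out. For the compounds shown here, this is the first look at the group on a nitrogen on an aromatic ring, and with the hexyl group kept, this position accepts a marked change in the group attached to it: the chlorine is gone, the entering group has more heavy atoms, and it brings hydrogen-bond acceptors that 4-chlorophenyl lacks, yet the number stays within the usual scatter. No evidence here explains why two such different groups give such similar numbers.

What the compounds shown leave open is whether 3,5-dimethoxyphenyl would behave the same way alongside the cyclohexyl group of compound 2, since the group on the nitrogen and the group on the other aromatic nitrogen may not act independently. Going by these compounds, it also remains open how far this tolerance extends, for example to a plain phenyl ring, a pyridine ring, or a phenyl ring carrying an amine or a carboxylic acid.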